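Phenyl in place of methyl on the shared core

This account rests on a few compounds, and the source may have more. Where it says the series, first, only, none or still open, it means among the compounds named here.

Compound 1 `Cc1nc2c3ccccc3ccc2c2nc3c(ccc4ccccc43)c(-c3cc([N+](=O)[O-])ccc3N)c12` and compound 2 `Cc1nc2c3ccccc3ccc2c2nc3c(ccc4ccccc43)c(-c3cc(O)nc4ccccc34)c12` carry an aryl group on the core; compound 3 `Cc1nc2c3ccccc3ccc2c2nc3c(ccc4ccccc43)c(C)c12` carries a methyl there instead. In a functional assay on HeLa cells (Homo sapiens) for cytotoxicity, read by MTT assay, with a stated time of 48 h (on this read-out higher numbers stand for weaker inhibition and lower numbers for stronger inhibition), compound 1 gives 5770 nM and compound 2 gives 4880 nM, two values that lie within the scatter of each other a 1.2-fold lower number from compound 1 to compound 2 (0.07 log units; within the scatter). In this assay compound 3 gives > 80000 nM, which is a limit of the assay rather than a number. Compound 3 therefore stands at the weak end of the three, sitting at the limit of > 80000 nM in this assay, at which 1 of the 3 values shown sits, the only one of the three without a measured value.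

Compound 4 `Cc1nc2c3ccccc3ccc2c2nc3c(ccc4ccccc43)c(-c3ccccc3)c12` changes compound 3 by phenyl in place of methyl on an aromatic carbon. For the measured compounds named here, the steps that bear on this are the two in the opposite direction: an at least 13-fold higher number from compound 1 to compound 3 (1.14 log units; beyond the scatter) and an at least 16-fold higher number from compound 2 to compound 3 (1.21 log units; beyond the scatter), both large and both beyond the scatter. Restoring an aryl group at the same place is thus expected to move the number down by a large step, though phenyl lacks the substituents of the aryl groups in compound 1 and compound 2, so the size is uncertain. For compound 4 in this assay a value of 10000 nM is estimated, expected to lie between 3500 nM and 40000 nM. The step expected from compound 3 to compound 4 is an at least 8.0-fold lower number from compound 3 to compound 4 (0.90 log units; beyond the scatter).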

Compound 4, half-maximal inhibitory concentration: > 80000 nM
Compound 4 ended at the assay's limit (the forecaster's own chance of this, stated with the estimate: 20%); middle value at least 8.0-fold (0.90 log units) from the limit.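

Phenyl alone does not bring back the effect of the two larger aryl groups at this position. In this assay, putting phenyl in place of 2-hydroxyquinolin-4-yl gives an at least 16-fold higher number from compound 2 to compound 4 (1.21 log units; beyond the scatter), and putting phenyl in place of 2-amino-5-nitrophenyl gives an at least 13-fold higher number from compound 1 to compound 4 (1.14 log units; beyond the scatter), so among these compounds an unsubstituted six-membered aromatic ring on this aromatic carbon is not enough to give a measurable value. Compound 3 and compound 4 both end at the assay's limit, so the step between methyl and phenyl cannot be read, and the two can only be placed together at the weak end of the set: the limit of > 80000 nM in this assay, at which 2 of the 4 values shown sit.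

The compounds shown leave open which part of the two larger groups matters: the amino group, the nitro group, the hydroxyl or the second ring of the quinoline. A phenyl carrying only an amine, only a nitro group or a carboxylic acid, set beside a plain quinolin-4-yl, would begin to separate these possibilities and show whether a single substituent on the ring is enough.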